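A few compounds are considered here, and "the series" means these few. Any claim that something is new, unique, unknown or untested is made for them only; others in the source may bear on it.

Working notes on the series. The shared core is held constant; the compounds differ only in the group on one aromatic carbon of the ring carrying two isopropyl groups. Compound 1 `COc1cc(C(C)C)c(OC(=O)NS(=O)(=O)Oc2c(C(C)C)cccc2C(C)C)c(C(C)C)c1` bears a methoxy there; in an assay on liver for inhibition of sterol O-acyltransferase 1 (Rattus norvegicus), using microsomes (a lower number here means a stronger inhibitor, a higher number a weaker inhibitor), compound 1 gives > 25000 nM, which is a limit of the assay and not a number. Compound 2 `CC(C)c1cc(Cl)cc(C(C)C)c1OC(=O)NS(=O)(=O)Oc1c(C(C)C)cccc1C(C)C` bears a chloro; in this assay compound 2 gives 42000 nM. Compound 3 `CC(C)c1cc(F)cc(C(C)C)c1OC(=O)NS(=O)(=O)Oc1c(C(C)C)cccc1C(C)C` bears a fluoro; in this assay compound 3 gives > 50000 nM, again a limit of the assay rather than a number. Among the measured compounds shown here, compound 3 thus stands at the weak end of what the assay can read, and only the step of an at least 1.1-fold higher number from compound 2 to compound 3 (0.07 log units; that floor lies within the scatter) is readable at all, while a step that the limit leaves unreadable from compound 1 to compound 2 and a step that the two limits leave unreadable from compound 1 to compound 3 cannot be sized. Compound 4 `CC(C)c1cc(O)cc(C(C)C)c1OC(=O)NS(=O)(=O)Oc1c(C(C)C)cccc1C(C)C` differs from compound 3 by hydroxy in place of fluoro on an aromatic carbon. For the measured compounds named here, no measured step exchanges a halogen for a hydroxy, so nothing among compounds 1, 2 and 3 sets a direction; all three sit at or beyond the upper edge of the range. In this assay compound 4 is expected near 50000 nM, in the range 20000 nM to 150000 nM. The expected step of a number no higher from compound 3 to compound 4 (the limit leaves the size open) is estimated as none beyond the scatter.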

Compound 4, half-maximal inhibitory concentration: > 50000 nM
Compound 4: only a limit was reported; the forecaster's own chance of this, stated with the estimate: 60%; the middle value sits exactly at the limit.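

In this assay compound 4 gives > 50000 nM, which is a limit of the assay and not a number. Hydroxy, which enters with 1 hydrogen-bond donor and 1 hydrogen-bond acceptor in place of fluoro, therefore does not bring this position into the readable range. The only readable comparison is with the chloro, an at least 1.1-fold higher number from compound 2 to compound 4 (0.07 log units; that floor lies within the scatter), while the steps to compound 4 from compound 1 and compound 3 cannot be read, and the series remains pressed against the same ceiling: the limit of > 50000 nM in this assay, at which 2 of the 4 values shown sit.

Whether any group on this aromatic carbon can give a readable inhibitor stays open, since an amine, a carboxylic acid and a longer alkyl chain are not among the compounds shown. On these data alone, the order among methoxy, fluoro and hydroxy also stays open.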